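The compounds below may be only part of what the source reports. "The series", "measured", "known", "first", "only" and "open" are said of these compounds alone.

Measured so far in a functional assay on K562 cells (Homo sapiens) for cytotoxicity, read by MTT assay, with a stated time of 48 h; on this read-out higher numbers stand for weaker inhibition and lower numbers for stronger inhibition:
Compound 1 `CCOC(=O)[C@]1(C(=O)Nc2ccccc2)C[C@@H]1c1cc(OC)c(OC)c(OC)c1` gives only a limit, > 100000 nM.
Compound 2 `CCOC(=O)[C@@]1(C(=O)Nc2ccccc2Cl)C[C@H]1c1cc(OC)c(OC)c(OC)c1` likewise gives only a limit, > 100000 nM.
Compound 3 `COc1cc([C@H]2C[C@]2(CO)C(=O)Nc2ccccc2)cc(OC)c1OC` also gives only a limit, > 100000 nM.

Compound 3 arises from compound 1 through one change, (hydroxymethyl in place of ethoxycarbonyl on a saturated ring carbon). Since both values are limits, the step that the two limits leave unreadable from compound 1 to compound 3 cannot be read. How the core of compound 1 differs from the core of compound 2 is not broken down here. Compound 4 `COc1cc([C@@H]2C[C@@]2(CO)C(=O)Nc2ccccc2Cl)cc(OC)c1OC` has not yet been measured; it stands to compound 2 as compound 3 stands to compound 1, through the same change, (hydroxymethyl in place of ethoxycarbonyl on a saturated ring carbon). Among the compounds with values here, all values so far sit at the limit of > 100000 nM in this assay, at which 3 of the 3 values shown sit. On that basis the step that the limit leaves unreadable from compound 2 to compound 4 in this assay is expected, with no readable shift. For compound 4 the estimate is 150000 nM, most likely reported again only as a limit.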

Compound 4, half-maximal inhibitory concentration: 18400 nM
Beside the measured number, compound 4's estimate is 8.2-fold (0.91 log units) above it, outside the stated range (below it).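

In this assay, placing hydroxymethyl where ethoxycarbonyl stood on the saturated ring carbon gives an at least 5.4-fold lower number from compound 2 to compound 4 (0.73 log units; beyond the scatter), so on the core of compound 2 the change leads to a readable value. On the core of compound 1, the same change leaves compound 3 with only a limit, > 100000 nM. The step from the limit of compound 1 to the limit of compound 3 cannot be read, so the change is neither shown to carry over to that core nor shown to fail there, and most values offer no size to compare: the limit of > 100000 nM in this assay, at which 3 of the 4 values shown sit. On these data alone, it remains open whether the gain on the core of compound 2 is specific to hydroxymethyl. An amine, a carboxylic acid or a longer chain in the same place could give a smaller or larger step.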